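The compounds below may be only part of what the source reports. "The series", "measured", "known", "first", "only" and "open" are said of these compounds alone.

Of the compounds shown here, three of one shared core have been measured in a functional assay on PC-3 cells (Homo sapiens) for inhibition, read by sulforhodamine B assay, with a stated time of 48 h, tested at 10 uM; on this read-out higher numbers stand for more inhibition at the one concentration tested (going by the name of the read-out) and lower numbers for less inhibition. Compound 1 `Brc1cn2ccnc2c(-c2ccc3ncn(C4CCCCC4)c3c2)n1` gives 17.2%. Compound 2 `COc1ccc(-c2cn3ccnc3c(-c3ccc4ncn(C5CCCCC5)c4c3)n2)cc1` gives 95.2%. Compound 3 `Brc1ccc(-c2cn3ccnc3c(-c3ccc4ncn(C5CCCCC5)c4c3)n2)cc1` gives 42.4%. Compound 2 stands highest of the three, with compound 3 the nearest and compound 1 the furthest, and both gaps are beyond the usual scatter.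

Compound 4 `Fc1ccccc1-c1cn2ccnc2c(-c2ccc3ncn(C4CCCCC4)c3c2)n1` has not yet been measured. It differs from compound 2 in one place: 2-fluorophenyl in place of 4-methoxyphenyl on an aromatic carbon.

For the measured compounds named here, two measured steps bear on this. The step of a number 52.8 percentage points lower from compound 2 to compound 3 (beyond the scatter) shows that exchanging the methoxy of the phenyl for a bromo costs a great deal of inhibition in this assay. The steps of a number 78 percentage points higher from compound 1 to compound 2 (beyond the scatter) and a number 25.2 percentage points higher from compound 1 to compound 3 (beyond the scatter) show that adding a phenyl of either kind raises the number, but by very different amounts. Going by the values given here, compound 4 carries a phenyl without the methoxy, so a large drop from compound 2 is expected, landing nearer to compound 3, though the fluorine sits in a different spot and no step tests it directly. The expected step is a number 50.2 percentage points lower from compound 2 to compound 4 (beyond the scatter). Compound 4 is estimated at 45%, within the range 15% to 80%.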

Compound 4, a percentage reported as inhibition, at one concentration (the size of the read-out at that concentration, not a potency): 32.6%
Estimate against measurement, compound 4: 12.4 percentage points above; measured number inside the range.
By their numbers in this assay, from the lowest: compound 1; then compounds 4 and 3 (each within the scatter of the next); then compound 2.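

The new result shows that in this assay a phenyl at this position is not enough on its own to give a high number: 2-fluorophenyl in place of 4-methoxyphenyl gives a number 62.6 percentage points lower from compound 2 to compound 4 (beyond the scatter). The 2-fluorophenyl and 4-bromophenyl groups cannot be told apart here, with a number 9.8 percentage points lower from compound 3 to compound 4 (within the scatter), even though they differ in both the atom carried and its place on the phenyl, while 2-fluorophenyl in place of bromo still gives a number 15.4 percentage points higher from compound 1 to compound 4 (beyond the scatter). So, among the three phenyl-bearing compounds shown, a large rise over the bromo compound belongs to 4-methoxyphenyl alone, and no measurement is available that explains why this group stands apart.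

As far as these compounds go, because the step to 2-fluorophenyl changes both the atom and its place at once, it remains open whether the methoxy itself or its place on the phenyl matters more; 2-methoxyphenyl and 4-fluorophenyl would separate those two changes. From the compounds shown here alone, it is also open whether the high number is special to methoxy or extends to other groups at the same place, such as an amine, a hydroxyl or a longer ethoxy chain.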